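This account rests on a few compounds, and the source may have more. Where it says the series, first, only, none or still open, it means among the compounds named here.

Compound 1 `COc1cc(-c2cc(/C=C/C(=O)c3ccc(N)cc3)[nH]n2)cc(OC)c1OC` is one of three measured analogues that share a core. In a functional assay on SK-OV-3 cells (Homo sapiens) for inhibition, read by sulforhodamine B assay, with a stated time of 48 h (a lower number here means that less compound is tolerated, a higher number that more compound is tolerated), compound 1 gives 28900 nM, the lowest of the three numbers, though compound 2 `COc1ccc(-c2cc(/C=C/C(=O)c3ccc(N)cc3)[nH]n2)cc1OC` with 41300 nM and compound 3 `COc1ccc(-c2cc(/C=C/C(=O)c3cc(OC)c(OC)c(OC)c3)[nH]n2)cc1OC` with 45500 nM both sit within the scatter of it. Within the data shown here, the only single-change step, a 1.4-fold higher number from compound 1 to compound 2 (0.16 log units; within the scatter), came with hydrogen in place of methoxy on an aromatic carbon and lies within the scatter. Compound 4 `COc1cc(-c2cc(/C=C/C(=O)c3ccc(F)c(F)c3)[nH]n2)cc(OC)c1OC` differs from compound 1 in another way: 3,4-difluorophenyl in place of 4-aminophenyl on a carbonyl carbon. Among the measured compounds shown here, no measured step bears on this particular change; the step from compound 1 to compound 2 concerned a methoxy group, and compound 3 differs from compound 1 in two places, so their values show only that all three lie close together. For this reason no step beyond the scatter in this assay is expected, a 1.1-fold lower number from compound 1 to compound 4 (0.03 log units; within the scatter). Compound 4 is estimated at 27000 nM, with a range from 8000 nM to 90000 nM.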

Compound 4, concentration lethal to 50% of the cells: > 100000 nM
Compound 4: a limit, no number (the forecaster's own chance of this, stated with the estimate: 10%); at least 3.7-fold (0.56 log units) between middle value and limit.
By their numbers in this assay, from the lowest: compounds 1, 2 and 3 (each within the scatter of the next). At a limit, above all of these: compound 4.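

The change from 4-aminophenyl to 3,4-difluorophenyl on a carbonyl carbon brought an at least 3.4-fold higher number from compound 1 to compound 4 (0.53 log units; beyond the scatter) and is the only step shown that lies beyond the scatter. The group at this position therefore moves the number in this assay, whereas the methoxy change did not move it beyond the scatter. In this assay compound 4 gives > 100000 nM, which is a limit and not a number, so the step has a lower bound but no measured size: the limit of > 100000 nM in this assay, at which 1 of the 4 values shown sits.

The whole aromatic group changes in this step, so the compounds shown cannot separate the loss of the amino group from the entry of the two fluorines. As far as these compounds go, an unsubstituted phenyl or a 4-hydroxyphenyl on the same carbon would bear on that question, and whether the step holds on the core of compound 2 also stays open.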